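Swapping an Amide Heterocycle Under a Cytotoxicity Limit

The compounds below may be only part of what the source reports. "The series", "measured", "known", "first", "only" and "open" are said of these compounds alone.

Compound 1 `O=C(Cn1c(-c2ccccc2)cc(-c2ccccc2)c1-c1ccccc1)Nc1nc2ccccc2s1` and compound 2 `CCc1nnc(NC(=O)Cn2c(-c3ccccc3)cc(-c3ccccc3)c2-c2ccccc2)s1` share one core, while compound 3 `O=C(Cn1c(-c2ccccc2)cc(-c2ccco2)c1-c1ccco1)Nc1nc2ccccc2s1` and compound 4 `CCc1nnc(NC(=O)Cn2c(-c3ccccc3)cc(-c3ccco3)c2-c2ccco2)s1` share another; the difference between the two cores is not broken down here. In an ADME assay on HEK-293T cells (Homo sapiens) for cytotoxicity, read by MTT assay, with a stated time of 72 h (a lower number here means a stronger inhibitor, a higher number a weaker inhibitor), compound 1 gives only a limit, < 50000 nM. Compound 2 likewise gives only a limit in this assay, < 50000 nM. Compound 3 also reaches only a limit in this assay, < 50000 nM. Compound 2 differs from compound 1 by 5-ethyl-1,3,4-thiadiazol-2-yl in place of 1,3-benzothiazol-2-yl on an amide-type nitrogen, and the resulting step that the two limits leave unreadable from compound 1 to compound 2 cannot be read because of the limit of < 50000 nM in this assay, at which 3 of the 3 values shown sit. Compound 4 carries the same change relative to compound 3, (5-ethyl-1,3,4-thiadiazol-2-yl in place of 1,3-benzothiazol-2-yl on an amide-type nitrogen). That change has already been measured as a step that the two limits leave unreadable from compound 1 to compound 2. The step is expected to be a step that the limit leaves unreadable from compound 3 to compound 4. Compound 4 is therefore estimated at 30000 nM, plausibly between 5000 nM and 50000 nM, with a limit again likely.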

Compound 4, half-maximal inhibitory concentration: < 50000 nM
Compound 4: only a limit was reported; the forecaster's own chance of this, stated with the estimate: 80%; the middle value does not contradict the limit.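

No step can be read from compound 3 to compound 4, because both give only a limit: the limit of < 50000 nM in this assay, at which 4 of the 4 values shown sit.

The compounds shown leave open how large any value in this assay truly is, and whether placing 5-ethyl-1,3,4-thiadiazol-2-yl in place of 1,3-benzothiazol-2-yl changes it at all.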